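Adding a Methoxy Group to a Weakly Cytotoxic Lignan-Type Series

A few compounds are considered here, and "the series" means these few. Any claim that something is new, unique, unknown or untested is made for them only; others in the source may bear on it.

Measured compounds:
compound 1, `COc1ccc([C@H](O)[C@H]2CO[C@@H](c3ccc(OC)c(OC)c3)[C@H](C/C=C/c3ccccc3)C2)cc1OC`, 16100 nM
compound 2, `COc1ccc(/C=C/C[C@@H]2C[C@@H]([C@@H](O)c3ccc(OC)c(OC)c3)CO[C@H]2c2ccc(OC)c(OC)c2)cc1`, 17100 nM
compound 3, `COc1ccc([C@H]2OC[C@H]([C@@H](O)c3ccc(OC)c(OC)c3)C[C@@H]2C/C=C/c2ccc(OC)c(OC)c2)cc1`, 46700 nM

In a functional assay on HeLa cells (Homo sapiens) for cytotoxicity, read by WST assay, with a stated time of 48 h (on this read-out higher numbers stand for weaker inhibition and lower numbers for stronger inhibition), compound 1 gives 16100 nM and compound 2 gives 17100 nM. The change between them is methoxy in place of hydrogen on an aromatic carbon and gave a 1.1-fold higher number from compound 1 to compound 2 (0.03 log units; within the scatter). Compound 3 gives 46700 nM; the difference between the two cores is not broken down here. Compound 4, `COc1ccc(/C=C/C[C@H]2C[C@@H]([C@@H](O)c3ccc(OC)c(OC)c3)CO[C@@H]2c2ccc(OC)c(OC)c2)cc1OC`, has not been measured in this assay. It differs from compound 3 by methoxy in place of hydrogen on an aromatic carbon. This is the same kind of change as from compound 1 to compound 2, but the place differs: there the new methoxy sits para to a large group, here it sits ortho to a methoxy group and meta to a large group. Resting on a 1.1-fold higher number from compound 1 to compound 2 (0.03 log units; within the scatter) from compound 1 to compound 2, the step from compound 3 to compound 4 is expected to be small, a 1.1-fold higher number from compound 3 to compound 4 (0.03 log units; within the scatter). Compound 4 is estimated at 50000 nM, between 25000 nM and 100000 nM.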

Compound 4, half-maximal inhibitory concentration: 23800 nM
The estimate for compound 4 lay 2.1-fold (0.32 log units) above the measured number; measured number outside the range, below it.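

In this assay, swapping 4-methoxyphenyl for 3,4-dimethoxyphenyl gave a 2.0-fold lower number from compound 3 to compound 4 (0.29 log units; within the scatter), a step too small to separate from repeat-measurement noise. Set beside the earlier step, the same change cannot be told apart on the two cores: the same change on two cores in this assay, a 1.1-fold higher number (0.03 log units; within the scatter) from compound 1 to compound 2 and a 2.0-fold lower number (0.29 log units; within the scatter) from compound 3 to compound 4, 2.1-fold (0.32 log units) apart, within the scatter of two such steps. This shows that the change carried across these cores without a detectable difference, but it does not show that the two steps are identical, and two pairs with the methoxy group in different places give no general rule.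

The compounds shown leave open what an amine or a carboxylic acid would do on the same aromatic carbon in place of the methoxy group. On these data alone, whether either would give a step beyond the scatter also remains open.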